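Replacing the phenylcarbamoyl group of compound 1

This account rests on a few compounds, and the source may have more. Where it says the series, first, only, none or still open, it means among the compounds named here.

Compound 1 `O=C(Nc1ccccc1)c1cnc(NCc2c(F)ccc3c2CCO3)n2cnnc12` gives 14 mL.min-1.g-1
Compound 2 `Cc1ncccc1-c1cnc(NCc2c(F)ccc3c2CCO3)c2nn(CC#N)c(=O)n12` gives 151 mL.min-1.g-1

In an ADME assay on microsomes from liver (Homo sapiens) for metabolic stability, read by LC-MS, using NADPH, with stated times of 5 min and 30 min, tested at 1 uM (a lower number here means slower removal, a higher number faster removal of the compound), compound 1 holds the lower of the two numbers, and compound 2 lies above it by a margin beyond the scatter. Compound 3 `O=C1c2ccccc2CN1c1cnc(NCc2c(F)ccc3c2CCO3)n2cnnc12` keeps the core of compound 1 but differs on an aromatic carbon (a group of 10 heavy atoms (8 carbon, 1 nitrogen, 1 oxygen; one five-membered non-aromatic ring with 1 hetero atom, one six-membered aromatic ring of carbon only) in place of a group of 9 heavy atoms (7 carbon, 1 nitrogen, 1 oxygen; one six-membered aromatic ring of carbon only), on an aromatic carbon), where a group with a five-membered non-aromatic ring replaces the phenylcarbamoyl. Going by the values given here, no measured pair shows this change. Compound 1 at 14 mL.min-1.g-1 has room to rise, and a modest rise in this assay is expected, with a 2.5-fold higher number from compound 1 to compound 3 (0.40 log units; beyond the scatter) as the estimated step. For compound 3 the estimated value is 35 mL.min-1.g-1 with 14 mL.min-1.g-1 to 90 mL.min-1.g-1 as the expected range.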

Compound 3, intrinsic clearance in microsomes: 13 mL.min-1.g-1
The estimate for compound 3 lay 2.7-fold (0.43 log units) above the measured number; the whole stated range lies above it.
By their numbers in this assay, from the lowest: compounds 3 and 1 (each within the scatter of the next); then compound 2.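

At this aromatic carbon, in this assay, the group with a five-membered non-aromatic ring takes the place of the phenylcarbamoyl with a 1.1-fold lower number from compound 1 to compound 3 (0.03 log units; within the scatter). This exchange takes the hydrogen-bond donors of the group from 1 to 0, yet the number stays within the scatter in this single pair. Nothing at hand explains why the two groups read alike. As far as these compounds go, whether an amine, a carboxylic acid or a morpholine ring at this place would give a similar number stays open. So does whether this exchange would read the same on the core of compound 2.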